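The compounds below may be only part of what the source reports. "The series", "measured", "known", "first", "only" and "open" are said of these compounds alone.

Measured so far in a physicochemical assay for lipophilicity, using the shake flask method, in phosphate buffer, measured as octanol-water partition, at pH 7.4; on this read-out higher numbers stand for higher lipophilicity and lower numbers for lower lipophilicity:
- compound 1 `COc1cc(-c2cc(C(=O)O)c3ccccc3n2)ccc1OCC(=O)Nc1cccc(C)c1`: 1.5
- compound 2 `COc1cc(-c2cc(C(=O)O)c3ccccc3n2)ccc1OCC(=O)Nc1cccc(Cl)c1`: 2.3

Among the compounds with values here, compound 2 stands at the higher of the two numbers; compound 1 lies below it by the single measured step, a number 0.80 log units higher from compound 1 to compound 2 (beyond the scatter).

Compound 3 `COc1cc(-c2cc(C(=O)O)c3ccccc3n2)ccc1OCC(=O)NCc1ccccc1` is not yet measured in this assay. Its change against compound 2 is benzyl in place of 3-chlorophenyl on an amide-type nitrogen. Within the data shown here, the only measured step is a number 0.80 log units higher from compound 1 to compound 2 (beyond the scatter); it bears on the change only in part, since the chlorine that enters in that step leaves again here, but the methyl of compound 1 does not return and a benzyl takes the place of the ring on the amide-type nitrogen instead. Among the measured compounds shown here, no measured pair shows a benzyl against an aryl group on that nitrogen. Reading the chlorine loss backwards from a number 0.80 log units higher from compound 1 to compound 2 (beyond the scatter), and lacking any number for the benzyl itself, a drop beyond the scatter is expected, landing near compound 1. The step from compound 2 is expected to be a number 0.90 log units lower from compound 2 to compound 3 (beyond the scatter). Compound 3 is therefore estimated at 1.4, with a range from 0.9 to 1.9.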

Compound 3, distribution coefficient: 0.4
The estimate for compound 3 lay 1.00 log units above the measured number; measured number outside the range, below it.
By their numbers in this assay, from the lowest: compound 3; then compound 1; then compound 2.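

In this assay, the position on the amide-type nitrogen responds far more strongly to the change of group than to the substituent on the ring: a number 1.90 log units lower from compound 2 to compound 3 (beyond the scatter), and a number 1.10 log units lower from compound 1 to compound 3 (beyond the scatter), both printed as large, whereas a number 0.80 log units higher from compound 1 to compound 2 (beyond the scatter) is modest. The drop therefore appears against both the 3-chlorophenyl and the 3-methylphenyl compound, placing compound 3 lowest of the series even though benzyl and 3-chlorophenyl have the same heavy-atom count and each has one six-membered aromatic ring of carbon only. Nothing available here accounts for the size of this drop.

The compounds shown leave open whether the chloro for methyl step carries over to the benzyl series, as a 3-chlorobenzyl and a 3-methylbenzyl on the same nitrogen would show. They also leave open how an unsubstituted phenyl or a longer chain such as 2-phenylethyl would fall relative to compound 3 on this read-out, which would separate the effect of the ring substituent from that of the chain.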